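This account rests on a few compounds, and the source may have more. Where it says the series, first, only, none or still open, it means among the compounds named here.

Of the compounds shown here, three that share one core have been measured in a functional assay for inhibition, with Rattus norvegicus as the target; on this read-out higher numbers stand for weaker inhibition and lower numbers for stronger inhibition. Compound 1 `CCCCc1cc(OC)c2c(C)cc(C)c(C)c2c1OC(C)=O` gives 11900 nM. Compound 2 `CCCCc1cc(OC)c2c(C)ccc(C)c2c1OC(C)=O` gives 7350 nM. Compound 3 `CCc1c(CC)c(OC)c2c(C)cccc2c1OC(C)=O` gives 830 nM, the lowest of the three numbers; its gap to compound 2 and its gap to compound 1 both lie beyond the usual scatter of repeated measurements.

Compound 2 and compound 1 differ in a single place: methyl in place of hydrogen on an aromatic carbon. The resulting step, a 1.6-fold higher number from compound 2 to compound 1 (0.21 log units; within the scatter), is small enough to count as noise. How the core of compound 3 differs from the core of compound 2 is not broken down here.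

Compound 4 `CCc1c(CC)c(OC(C)=O)c2c(C)ccc(C)c2c1OC` has not yet been measured. It differs from compound 3 in one place: methyl in place of hydrogen on an aromatic carbon. Among the measured compounds shown here, this is the same kind of change as the one from compound 2 to compound 1, but the surroundings are not identical: in compound 4 the incoming methyl sits ortho to a fused ring, meta to a fused ring and para to a methyl group, whereas in compound 1 it sits ortho to a methyl group, meta to a fused ring, meta to a methyl group and para to a fused ring.

Because the earlier step of a 1.6-fold higher number from compound 2 to compound 1 (0.21 log units; within the scatter) stayed within the scatter, a similarly modest shift is expected from compound 3 to compound 4, namely a 1.4-fold higher number from compound 3 to compound 4 (0.16 log units; within the scatter). Compound 4 is therefore estimated at 1200 nM. For compound 4 the likely range is expected to run from 450 nM to 3200 nM.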

Compound 4, half-maximal inhibitory concentration: 13000 nM
Beside the measured number, compound 4's estimate is 11-fold (1.03 log units) below it, and the stated range ends below it.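

In this assay, putting a methyl in place of a hydrogen on an aromatic carbon of the core of compound 3 gives a 16-fold higher number from compound 3 to compound 4 (1.19 log units; beyond the scatter), so on this core the small change costs a large loss of inhibition. The same swap on the other core left the number within the scatter, and the two steps clearly disagree: the same change on two cores in this assay, a 1.6-fold higher number (0.21 log units; within the scatter) from compound 2 to compound 1 and a 16-fold higher number (1.19 log units; beyond the scatter) from compound 3 to compound 4, 9.7-fold (0.99 log units) apart, beyond the scatter of two such steps. Among the compounds shown here, this shows that the size of the methyl effect measured on one core cannot simply be carried over to another core, although with only two pairs it does not show what sets them apart, whether the rest of the core or the surroundings of the incoming methyl, nor does it give a rule for predicting the step on a further core.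

The compounds shown leave open how a group other than methyl, such as an amine or a carboxylic acid, would behave on the same aromatic carbon of either core. They also leave open whether a third core would follow the small step, the large one, or something in between.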